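The source may hold more compounds than are shown below. What is called first, only, known or untested is meant among the compounds shown, and "the series" means these compounds.

Working notes on the series.

Within the data shown here, compound 1 `CCCCNc1nc(SC)nc2ncccc12` carries a butylamino group on the shared core; in a functional assay (Nicotiana tabacum) (a lower number here means a stronger inhibitor, a higher number a weaker inhibitor), compound 1 gives 270 nM, the lowest of the three numbers so far. Compound 2 `CCCCCNc1nc(SC)nc2ncccc12` is the pentyl analogue, and in this assay compound 2 gives 650 nM; the step of a 2.4-fold higher number from compound 1 to compound 2 (0.38 log units; beyond the scatter) is the only one among the three that falls beyond the scatter. Compound 3 `CSc1nc(NC2CCCC2)c2cccnc2n1` has a cyclopentyl group on the same nitrogen and in this assay compound 3 gives 490 nM; the step of a 1.8-fold higher number from compound 1 to compound 3 (0.26 log units; within the scatter) and the step of a 1.3-fold lower number from compound 2 to compound 3 (0.12 log units; within the scatter) both stay within the scatter.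

Compound 4 `C=CCNc1nc(SC)nc2ncccc12` differs from compound 1 by vinyl in place of propyl on a saturated chain carbon bound to a nitrogen on an aromatic ring, that is, butylamino to allylamino. Among the measured compounds shown here, no measured pair covers a shortening of the chain or a double bond in it; the only chain-length step, the one from compound 1 to compound 2, went to a higher number on adding carbon. Shortening the chain below butyl is uncharted, so the expectation for compound 4 is a number close to that of compound 1, with wide uncertainty in both directions, which is written as the step of a 1.2-fold higher number from compound 1 to compound 4 (0.07 log units; within the scatter). For compound 4 in this assay the estimate is 320 nM, in the range 120 nM to 900 nM.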

Compound 4, half-maximal inhibitory concentration: 400 nM
Estimate against measurement, compound 4: 1.3-fold (0.10 log units) below, and the stated range covers the measured number.
By their numbers in this assay, from the lowest: compounds 1, 4, 3 and 2 (each within the scatter of the next, the first and the last beyond it).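

In this assay, among these compounds, butylamino to allylamino is the first change at this nitrogen that both shortens the chain and brings in a double bond, and a 1.5-fold higher number from compound 1 to compound 4 (0.17 log units; within the scatter) stays small enough that allyl cannot be told apart from butyl. Allyl also cannot be told apart from the other two groups on this nitrogen, with a 1.2-fold lower number from compound 3 to compound 4 (0.09 log units; within the scatter) and a 1.6-fold lower number from compound 2 to compound 4 (0.21 log units; within the scatter) both small, so compound 4 sits within the scatter of compound 2 even though compound 1 and compound 2 are separated by more than the scatter; the four numbers therefore show no firm dependence on chain length, and the one step beyond the scatter remains that between butyl and pentyl. No measurement on hand bears on the reason for these numbers.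

The step from butyl to allyl changes chain length and saturation together, and a saturated propyl group on the same nitrogen would be needed to separate the two. Still open, from the compounds shown here alone, is how this position responds to a much smaller group such as methyl, or to a chain ending in an amine or a carboxylic acid.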